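A few compounds are considered here, and "the series" means these few. Any claim that something is new, unique, unknown or untested is made for them only; others in the source may bear on it.

Values from a functional assay on MCF7 cells (Homo sapiens) for antiproliferative activity, read by MTT assay, with a stated time of 48 h (on this read-out higher numbers stand for weaker inhibition and lower numbers for stronger inhibition), for the series so far
Compound 1 (`COc1ccc(-c2c(Nc3cc(OC)c(OC)c(OC)c3)c3ccccc3oc2=O)cc1`): 82300 nM
Compound 2 (`COc1ccc(-c2c(Nc3ccc(F)cc3)c3ccccc3oc2=O)cc1`): 38500 nM

Compound 2 holds the lower of the two numbers, so it is the stronger inhibitor of the pair, beyond the scatter. Compound 3 (`COc1ccc(-c2c(Nc3ccc(C)c(O)c3)c3ccccc3oc2=O)cc1`) has 3-hydroxy-4-methylphenyl in place of 4-fluorophenyl on a nitrogen on an aromatic ring. Within the data shown here, no measured pair isolates this change. The expectation therefore rests on the modest gap between compound 2 at 38500 nM and compound 1 at 82300 nM in this assay. A modest move towards stronger inhibition is expected (a 1.9-fold lower number from compound 2 to compound 3 (0.28 log units; within the scatter)). Compound 3 is estimated at 20000 nM, with an expected range of 6000 nM to 70000 nM.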

Compound 3, half-maximal inhibitory concentration: 12100 nM
Beside the measured number, compound 3's estimate is 1.7-fold (0.22 log units) above it; the range from low to high includes it.
By their numbers in this assay, from the lowest: compound 3; then compound 2; then compound 1.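

In this assay, among these compounds, the substituent at this position moves the read-out: 3-hydroxy-4-methylphenyl in place of 4-fluorophenyl on a nitrogen on an aromatic ring gives a 3.2-fold lower number from compound 2 to compound 3 (0.50 log units; beyond the scatter) and is the first single change that can be read as a step. Nothing available explains this step.

As far as these compounds go, the hydroxy and methyl groups enter together, so their separate contributions stay open. From the compounds shown here alone, how an amine or a carboxylic acid on the same ring would read also remains open.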